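The source may hold more compounds than are shown below. What is called first, only, known or untested is meant among the compounds shown, and "the series" means these compounds.

Measured so far in an assay on membranes from HeLa cells for displacement of a labelled ligand from adenosine receptor A3 (Homo sapiens), read by scintillation counting, with a stated time of 180 min, tested at 1 uM; a higher number here means more inhibition at the concentration tested (going by the name of the read-out), a lower number less inhibition:
Compound 1 `CC1=C(C(=O)OC(C)(C)C)C(c2ccsc2)NC(=O)N1` gives 1%.
Compound 2 `CC1=C(C(=O)OCc2ccccc2)C(c2ccsc2)NC(=O)N1` gives 25%.
Compound 3 `CC1=C(C(=O)OC(C)(C)C)C(c2cccs2)NC(=S)N1` gives 22%.

Compound 1 and compound 2 share one core and differ only in benzyl in place of tert-butyl on an oxygen next to a carbonyl group. That change made the step of a number 24 percentage points higher from compound 1 to compound 2 (beyond the scatter). Compound 3 has a different core; how its core differs from the core of compound 1 is not broken down here. Compound 4 `CC1=C(C(=O)OCc2ccccc2)C(c2cccs2)NC(=S)N1` is not yet measured; it differs from compound 3 in benzyl in place of tert-butyl on an oxygen next to a carbonyl group, the same change as between compound 1 and compound 2.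

Since this change occurs only twice among the compounds shown, the expectation rests on a single earlier step. The step from compound 3 to compound 4 is expected to be a number 20 percentage points higher from compound 3 to compound 4 (beyond the scatter), beside the step of a number 24 percentage points higher from compound 1 to compound 2 (beyond the scatter). Compound 4 is therefore estimated to give around 42% in this assay, with a likely span from 18% to 66%.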

Compound 4, a percentage reported as inhibition, at one concentration (the size of the read-out at that concentration, not a potency): 24%
Estimate against measurement, compound 4: 18 percentage points above, and the stated range covers the measured number.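

In this assay, benzyl in place of tert-butyl now gives a step of a number 2 percentage points higher from compound 3 to compound 4 (within the scatter). The change therefore did not behave alike on the two cores, and its gain on one core cannot simply be added to a compound with the other: the same change on two cores in this assay, a number 24 percentage points higher (beyond the scatter) from compound 1 to compound 2 and a number 2 percentage points higher (within the scatter) from compound 3 to compound 4, 22 percentage points apart, beyond the scatter of two such steps. The data do not show which difference between the cores accounts for this, nor how the change would behave on a third core.

Still open, on these data alone, is how other groups on the oxygen next to the carbonyl group would fare, such as ethyl or a longer chain ending in an amine. These percentages also come from a single concentration, so they leave the potency of each compound open.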